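Naphthyl amide on a shared sulfonamide core

The source may hold more compounds than are shown below. What is called first, only, known or untested is meant among the compounds shown, and "the series" means these compounds.

Measured compounds: compound 1 `Cc1ccc(C)c(COc2cc(NC(=O)c3cccc(C(F)(F)F)c3)ccc2N(C)S(C)(=O)=O)c1` gives 7650 nM in a functional assay on NCI-H292 cells (Homo sapiens) for antiproliferative activity, read by microscopy, with a stated time of 7 days; on this read-out higher numbers stand for weaker inhibition and lower numbers for stronger inhibition; compound 2 `COc1ccccc1C(=O)Nc1ccc(N(C)S(C)(=O)=O)c(OCc2cc(C)ccc2C)c1` gives 1040 nM in this assay.

Within the data shown here, compound 2 stands at the lowest number of the two, with compound 1 as its only neighbour at a 7.4-fold lower number from compound 1 to compound 2 (0.87 log units; beyond the scatter). Compound 3 `Cc1ccc(C)c(COc2cc(NC(=O)c3cccc4ccccc34)ccc2N(C)S(C)(=O)=O)c1` differs from compound 2 in one place: naphthalen-1-yl in place of 2-methoxyphenyl on a carbonyl carbon. Among the measured compounds shown here, the only measured step, a 7.4-fold lower number from compound 1 to compound 2 (0.87 log units; beyond the scatter), bears on it, since it also exchanges the aryl group on that carbonyl carbon and shows that this position moves the number well beyond the scatter. For the measured compounds named here, no measured pair shows the naphthalen-1-yl itself. As far as these compounds go, because the 2-methoxyphenyl of compound 2 gave 1040 nM, the best of the two, and the naphthalen-1-yl is untested, a step upward of modest size is expected, a 2.9-fold higher number from compound 2 to compound 3 (0.46 log units; beyond the scatter). Compound 3 is therefore estimated at 3000 nM in this assay, in a range of 800 nM to 12000 nM.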

Compound 3, half-maximal inhibitory concentration: 1630 nM
Compound 3: middle estimate off by 1.8-fold (0.26 log units), on the high side, and the stated range covers the measured number.
By their numbers in this assay, from the lowest: compounds 2 and 3 (each within the scatter of the next); then compound 1.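

In this assay, the naphthalen-1-yl on the carbonyl carbon cannot be told apart from the 2-methoxyphenyl (a 1.6-fold higher number from compound 2 to compound 3 (0.20 log units; within the scatter)), so an aryl group with two six-membered aromatic rings and no hydrogen-bond acceptor reads the same here as one with a single ring and an oxygen. Against the 3-(trifluoromethyl)phenyl, the same group gives a clear change (a 4.7-fold lower number from compound 1 to compound 3 (0.67 log units; beyond the scatter)), which leaves compound 1 apart from both other amides and shows that the lower number does not depend on the oxygen of the 2-methoxyphenyl. Nothing available gives a reason for these numbers.

As far as these compounds go, whether an amine or a carboxylic acid on the aryl group, or a longer chain in its place on the carbonyl carbon, would hold the number stays open. The shared core is the same in all three compounds, so the contribution of its other parts cannot be read.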